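The source may report more compounds than this note shows. Statements on the series, on what has been measured and on what is new or still open speak of the compounds shown alone.

Measured compounds:
- compound 1, `Cn1nc2c(=O)n(CC3(O)CCN(Cc4ccc(-c5ccco5)cc4Cl)CC3)cnc2c1-c1ccc(CNS(C)(=O)=O)cc1`: 65.3 nM
- compound 2, `Cn1nc2c(=O)n(CC3(O)CCN(Cc4ccc(-c5cccs5)cc4Cl)CC3)cnc2c1-c1ccc(CN)cc1`: 38.6 nM
- compound 3, `Cn1nc2c(=O)n(CC3(O)CCN(Cc4ccc(-c5cncs5)cc4Cl)CC3)cnc2c1-c1ccc(CN)cc1`: 117 nM

All three were tested in an assay on isolated protein for inhibition of ubiquitin carboxyl-terminal hydrolase 7 (Homo sapiens), with stated times of 30 min and 2 h; a lower number here means a stronger inhibitor, a higher number a weaker inhibitor. Compound 1, with its (methanesulfonamido)methyl group, gives 65.3 nM, which stands second highest of the three numbers; its distance to compound 2 and its distance to compound 3 each lie within the usual scatter, so none of the three can be called clearly stronger or weaker than compound 1. Among the compounds with values here, the only step that is clearly beyond the scatter runs between compounds sharing the primary amine: a 3.0-fold higher number from compound 2 to compound 3 (0.48 log units; beyond the scatter). That step concerns the five-membered aromatic ring on the other side of the molecule and does not touch the amine nitrogen.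

Compound 4, `Cn1nc2c(=O)n(CC3(O)CCN(Cc4ccc(-c5ccco5)cc4Cl)CC3)cnc2c1-c1ccc(CNC2CC2)cc1`, differs from compound 1 at that amine nitrogen: cyclopropyl in place of methylsulfonyl on an amine nitrogen. Within the data shown here, no measured pair shows this exchange, so the expectation rests on the fact that the primary amine of compound 2 and the methanesulfonamide of compound 1 sit within the scatter of each other in this assay. A cyclopropylamino group is expected to behave similarly, giving a step of about a 1.3-fold lower number from compound 1 to compound 4 (0.12 log units; within the scatter), that is, nothing beyond the scatter. Compound 4 is therefore estimated at 50 nM, with a range from 20 nM to 130 nM.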

Compound 4, half-maximal inhibitory concentration: 54.1 nM
Compound 4: middle estimate off by 1.1-fold (0.03 log units), on the low side; measured number inside the range.
By their numbers in this assay, from the lowest: compounds 2, 4, 1 and 3 (each within the scatter of the next, the first and the last beyond it).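

In this assay, within the data shown here, putting cyclopropyl in place of methylsulfonyl on the amine nitrogen gives a 1.2-fold lower number from compound 1 to compound 4 (0.08 log units; within the scatter), the first direct reading of a change at this position, as the compounds with the primary amine differ from compound 1 in a second place as well. The two groups share little: methylsulfonyl counts four heavy atoms, including sulfur and two oxygens, and two hydrogen-bond acceptors, whereas cyclopropyl is a three-membered ring of carbon only with no acceptors, yet this pair shows that such an exchange at this nitrogen need not move the number beyond the scatter. No measurement at hand explains why two such different groups give numbers this close.

As far as these compounds go, what remains open is how far this tolerance extends, for example whether an acetyl group, a longer chain such as n-butyl, or a carboxylic acid-bearing chain on the same nitrogen would also stay within the scatter. From the compounds shown here alone, it is also open whether the same exchange would read alike with thiophen-2-yl or 1,3-thiazol-5-yl in place of the five-membered ring that compound 1 and compound 4 share.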